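Ester Substituent Change on a Nitroanilide Cyclohexane Series

The source may hold more compounds than are shown below. What is called first, only, known or untested is meant among the compounds shown, and "the series" means these compounds.

Compound 1, `Cc1ccc(C(=O)OC2(C(=O)Nc3ccc([N+](=O)[O-])cc3)CCCCC2)cc1`: 45.4 nM
Compound 2, `COc1ccc(C(=O)OC2(C(=O)Nc3ccc([N+](=O)[O-])cc3)CCCCC2)cc1`: 38.8 nM

In a functional assay on NFS-60 cells (Mus musculus) for inhibition, read by MTT assay, with a stated time of 72 h (on this read-out higher numbers stand for weaker inhibition and lower numbers for stronger inhibition), compound 2 gives 38.8 nM, and compound 1 gives 45.4 nM; the two lie within the scatter of each other, so neither stands apart. Among the measured compounds shown here, the one measured step, a 1.2-fold lower number from compound 1 to compound 2 (0.07 log units; within the scatter), concerns the aromatic ring only. Compound 3, `CCC(=O)OC1(C(=O)Nc2ccc([N+](=O)[O-])cc2)CCCCC1`, is not yet measured; it differs from compound 2 by ethyl in place of 4-methoxyphenyl on a carbonyl carbon. For the measured compounds named here, no measured step bears on this change, so the expectation rests on the change alone. Compound 3 is expected at 120 nM (range 30 nM to 500 nM), a step of a 3.1-fold higher number from compound 2 to compound 3 (0.49 log units; beyond the scatter), weaker but with wide uncertainty.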

Compound 3, half-maximal inhibitory concentration: 6.4 nM
The estimate for compound 3 lay 19-fold (1.27 log units) above the measured number; measured number outside the range, below it.
By their numbers in this assay, from the lowest: compound 3; then compounds 2 and 1 (each within the scatter of the next).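

In this assay the step of a 6.1-fold lower number from compound 2 to compound 3 (0.78 log units; beyond the scatter) and the step of a 7.1-fold lower number from compound 1 to compound 3 (0.85 log units; beyond the scatter) show that the aromatic ring on this carbonyl carbon is not needed for a low number, and that ethyl does better here than either ring-bearing group. The earlier step changed only a substituent on that ring and stayed within the scatter, whereas replacing the whole ring moves the number beyond it. Nothing measured here accounts for this.

On these data alone, whether a methyl group, a propyl chain or a cyclohexyl group on the same carbonyl carbon would give a lower or higher number remains open. So does the effect of an amine carried on the ethyl chain.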